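The compounds below may be only part of what the source reports. "The series", "measured", "known", "first", "only" and "open" are said of these compounds alone.

Two compounds give a foothold in a functional assay for inhibition of sodium/hydrogen exchanger (Oryctolagus cuniculus); a lower number here means a stronger inhibitor, a higher number a weaker inhibitor. Compound 1 `Cc1c(C(=O)N=C(N)N)ccc(Cl)c1S(C)(=O)=O` gives 1300 nM, and compound 2 `Cc1cc(-c2ccc(Cl)cc2)c(S(C)(=O)=O)cc1C(=O)N=C(N)N` gives 45 nM. Compound 2 thus carries the lowest number of the two measured, and the gap to compound 1 lies well beyond the usual scatter. Among the measured compounds shown here, no pair of measured compounds differs in only one place, so no single step has been recorded here.

Compound 3 `Cc1cc(Sc2ccccc2)c(S(C)(=O)=O)cc1C(=O)N=C(N)N` is the next candidate. Its difference from compound 2 is phenylsulfanyl in place of 4-chlorophenyl on an aromatic carbon. The group that enters is a thioether rather than a directly joined aromatic ring, and nothing in the two measured compounds speaks directly to that change. Compound 3 is therefore expected to sit close to compound 2, and any step a 2.0-fold higher number from compound 2 to compound 3 (0.30 log units; within the scatter) is estimated to be small, with a slight lean toward a higher number. Compound 3 is estimated at 90 nM, within a range of 30 nM to 300 nM.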

Compound 3, half-maximal inhibitory concentration: 14 nM
Compound 3: middle estimate off by 6.4-fold (0.81 log units), on the high side; the whole stated range lies above it.
By their numbers in this assay, from the lowest: compound 3; then compound 2; then compound 1.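

In this assay, phenylsulfanyl in place of 4-chlorophenyl, on the aromatic carbon ortho to the methylsulfonyl group, gives a 3.2-fold lower number from compound 2 to compound 3 (0.51 log units; beyond the scatter). This shows that the position accepts an aryl group joined through sulfur as well as one joined directly, and that the thioether here carries the lower number, a difference beyond the usual scatter. The change swaps the link and removes the chlorine in one step, and no evidence bears on the reason for the difference.

The compounds shown cannot say whether the link or the loss of chlorine accounts for the step, a question that a plain phenyl or a 4-chlorophenylsulfanyl group at this position would separate. On these data alone, how a phenoxy group, with oxygen as the link, or a phenylamino group, with nitrogen as the link, would compare also remains open.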